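Methoxy for tert-butyl on the benzyl arm of compound 1

This account rests on a few compounds, and the source may have more. Where it says the series, first, only, none or still open, it means among the compounds named here.

Compound 1 `CC(C)(C)c1ccc(CNCCCNS(=O)(=O)c2cc(C(F)(F)F)cc(C(F)(F)F)c2)cc1` — 2300 nM
Compound 2 `O=[N+]([O-])c1ccc(S(=O)(=O)NCCCCCCNCc2ccc(Br)cc2)cc1` — 9800 nM
Compound 3 `O=S(=O)(NCCCCCCNCc1ccc(Br)cc1)c1ccc2c(c1)OCC2` — 13000 nM

These three compounds were tested in a functional assay on MIA PaCa-2 cells (Homo sapiens) for inhibition, read by MTT assay, with a stated time of 72 h; a higher number here means a weaker inhibitor of growth, a lower number a stronger inhibitor of growth. Compound 1 gives the lowest number of the three, with compound 2 closest and compound 3 furthest away. Within the data shown here, the one single-point step among them, a 1.3-fold higher number from compound 2 to compound 3 (0.12 log units; within the scatter), changes the group on the sulfonyl sulfur and lies within the scatter. Compound 4 `COc1ccc(CNCCCNS(=O)(=O)c2cc(C(F)(F)F)cc(C(F)(F)F)c2)cc1` differs from compound 1 in another place: methoxy in place of tert-butyl on an aromatic carbon. Among the measured compounds shown here, no measured step touches that position, so the measured steps say nothing direct about its size or direction; compounds 2 and 3 carry a different benzyl group but also differ elsewhere, so their higher numbers cannot be read as a guide. Compound 4 is therefore expected to give a modestly higher number, a 2.2-fold higher number from compound 1 to compound 4 (0.34 log units; beyond the scatter), with an estimate of 5000 nM and a range from 1800 nM to 14000 nM.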

Compound 4, concentration for 50% growth inhibition: 2500 nM
The estimate for compound 4 lay 2.0-fold (0.30 log units) above the measured number; the measured number falls inside the stated range.
By their numbers in this assay, from the lowest: compounds 1 and 4 (each within the scatter of the next); then compounds 2 and 3 (each within the scatter of the next).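

In this assay, placing methoxy where tert-butyl stood on the aromatic carbon of the benzyl arm gives a 1.1-fold higher number from compound 1 to compound 4 (0.04 log units; within the scatter). The growth-inhibition number of compound 1 therefore does not depend on keeping tert-butyl at this position, at least when methoxy replaces it. Nothing measured here explains why the two compounds read alike. As far as these compounds go, whether an amine or a carboxylic acid on this aromatic carbon would also leave the number unchanged remains open. So does whether a small group such as fluorine would.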